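This account rests on a few compounds, and the source may have more. Where it says the series, first, only, none or still open, it means among the compounds named here.

Working notes on the series. The shared core stands in compound 1 `O=C(Nc1ccc(Oc2ccnc3[nH]ccc23)cc1)c1nn(-c2ccc(Cl)c(C(F)(F)F)c2)ccc1=O`, which in a functional assay on HepG2 cells (Homo sapiens) for cytotoxicity, read by MTT assay, with a stated time of 72 h (a lower number here means a stronger inhibitor, a higher number a weaker inhibitor), gives 1320 nM. Compound 2 `COc1ccc(-n2ccc(=O)c(C(=O)Nc3ccc(Oc4ccnc5[nH]ccc45)c(F)c3)n2)cc1` carries a methoxy and a fluorine that compound 1 lacks; in this assay compound 2 reaches only a limit, > 60000 nM, namely (the limit of > 60000 nM in this assay, at which 1 of the 3 values shown sits). Compound 3 `O=C(Nc1ccc(Oc2ccnc3[nH]ccc23)c(F)c1)c1nn(-c2ccccc2)ccc1=O` keeps the fluorine but has a plain phenyl; in this assay compound 3 gives 24900 nM, the higher of the two numbers, compound 1 giving the lower. Among the measured compounds shown here, the one measured step, an at least 2.4-fold lower number from compound 2 to compound 3 (0.38 log units; beyond the scatter), favours the unsubstituted phenyl over its methoxy version. Compound 4 `O=C(Nc1ccc(Oc2ccnc3[nH]ccc23)c(F)c1)c1nn(-c2ccc(Cl)c(C(F)(F)F)c2)ccc1=O` differs from compound 3 by 4-chloro-3-(trifluoromethyl)phenyl in place of phenyl on an aromatic nitrogen. For the measured compounds named here, no measured step covers this change directly. Compound 1 already carries the same 4-chloro-3-(trifluoromethyl)phenyl and differs from compound 4 only by the absence of the fluorine, and its value lies well under that of compound 3, so the change is expected to bring compound 4 back toward compound 1. For compound 4 in this assay the expected step is a 17-fold lower number from compound 3 to compound 4 (1.22 log units; beyond the scatter). Compound 4 is estimated at 1500 nM, with a range from 500 nM to 5000 nM.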

Compound 4, half-maximal inhibitory concentration: 11900 nM
Compound 4: the middle estimate sits 7.9-fold (0.90 log units) below what was measured, and the stated range ends below it.
By their numbers in this assay, from the lowest: compound 1; then compound 4; then compound 3. At a limit, above all of these: compound 2.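

In this assay, with the fluorine held constant, 4-chloro-3-(trifluoromethyl)phenyl in place of phenyl on the aromatic nitrogen buys only a 2.1-fold lower number from compound 3 to compound 4 (0.32 log units; beyond the scatter), so this change alone is modest in the presence of the fluorine. With that aryl group held constant, fluoro in place of hydrogen on an aromatic carbon is the larger of the two steps, and it runs towards weaker inhibition: a 9.0-fold higher number from compound 1 to compound 4 (0.95 log units; beyond the scatter). Against the 4-methoxyphenyl version the same aryl group gives an at least 5.0-fold lower number from compound 2 to compound 4 (0.70 log units; beyond the scatter), a step that is only a bound since compound 2 stands at a limit: the limit of > 60000 nM in this assay, at which 1 of the 4 values shown sits.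

On these data alone, whether the fluoro step keeps its size with a plain phenyl on the aromatic nitrogen remains open. Also open, as far as these compounds go, is how that phenyl behaves with chlorine alone, with trifluoromethyl alone, or with an amine or a carboxylic acid.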